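Notes on a halogen exchange at the carbonyl-bound ring

A few compounds are considered here, and "the series" means these few. Any claim that something is new, unique, unknown or untested is made for them only; others in the source may bear on it.

Three compounds of the series have numbers in a functional assay on T47D cells (Homo sapiens) for inhibition, read by sulforhodamine B assay, with a stated time of 48 h; on this read-out lower numbers stand for stronger inhibition of growth and higher numbers for weaker inhibition of growth. Compound 1 `COc1ccc(-c2cc(/C=C/C(=O)c3ccc(OC)c(OC)c3)[nH]n2)cc1` gives 5150 nM. Compound 3 `COc1ccc(-c2cc(/C=C/C(=O)c3ccc(N)cc3)[nH]n2)cc1` gives 9770 nM. Compound 2 `COc1cc(-c2cc(/C=C/C(=O)c3ccc(Cl)c(Cl)c3)[nH]n2)cc(OC)c1OC` gives 15700 nM, the largest of the three numbers. The gap between compound 2 and compound 3 lies within the usual scatter, so those two cannot be told apart on this read-out; the gap to compound 1 lies beyond it, so compound 1 shows clearly stronger inhibition of growth than compound 2. Within the data shown here, no two of the measured compounds differ in a single place, so no measured step is available to guide the next change.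

Compound 4 `COc1cc(-c2cc(/C=C/C(=O)c3ccc(F)c(F)c3)[nH]n2)cc(OC)c1OC` is the next compound to be measured in this assay. It differs from compound 2 as follows: 3,4-difluorophenyl in place of 3,4-dichlorophenyl on a carbonyl carbon. Among the measured compounds shown here, nothing among the measured compounds speaks to this exchange; only the two halogens on the ring at the carbonyl carbon change, all else is held. The step in this assay is therefore expected to be small, in either direction, and most likely not beyond the usual scatter. The expected step is a 1.1-fold higher number from compound 2 to compound 4 (0.06 log units; within the scatter). For compound 4 the estimate is 18000 nM, with a range from 7000 nM to 45000 nM.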

Compound 4, concentration for total growth inhibition: 27000 nM
Compound 4: middle estimate off by 1.5-fold (0.18 log units), on the low side; the range from low to high includes it.
By their numbers in this assay, from the lowest: compounds 1, 3, 2 and 4 (each within the scatter of the next, the first and the last beyond it).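

This exchange gives the series its first step between compounds that differ in one place. In this assay the change to 3,4-difluorophenyl in place of 3,4-dichlorophenyl on a carbonyl carbon amounts to a 1.7-fold higher number from compound 2 to compound 4 (0.24 log units; within the scatter), so the two dihalogenated rings cannot be told apart on this read-out, and with all else held, this pair gives no sign that the choice between chlorine and fluorine at this place matters here. The data at hand contain nothing that could account for the size of this step, or for its direction within the scatter.

Still open, from the compounds shown here alone, is whether a group of another kind on the ring at the carbonyl carbon, such as a carboxylic acid, a dimethylamino group or a trifluoromethyl group in place of the two halogens, would give a step beyond the scatter from compound 2. Among these compounds, also open is whether the same exchange of chlorine for fluorine would give a similar step on the core of compound 1, since the only pair at hand carries it on the core of compound 2.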